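Series notes: tert-butyl in place of hydrogen on compound 2

The compounds below may be only part of what the source reports. "The series", "measured", "known", "first", "only" and "open" are said of these compounds alone.

Measured so far in a functional assay on cells for agonist activity at Free fatty acid receptor 1 (Homo sapiens), read by FLIPR and calcium flux, with a stated time of 100 s; on this read-out higher numbers stand for an effect only at larger amounts of compound and lower numbers for an effect already at smaller amounts:
compound 1 `O=C(O)C[C@@H]1CCCN1c1ccc(OCc2ccc(Cl)cc2Cl)cn1` gives 220 nM
compound 2 `O=C(O)C[C@@H]1CCCN1c1ccc(Oc2ccccc2)cc1` gives 560 nM
compound 3 `O=C(O)C[C@@H]1CCCN1c1ccc(Oc2ccc(Cl)cc2Cl)cc1` gives 360 nM

Compound 2 stands highest of the three numbers in this assay. The nearest number is reached by a 1.6-fold lower number from compound 2 to compound 3 (0.19 log units; within the scatter), a step that stays within the scatter; the furthest belongs to compound 1, whose number lies beyond the scatter from that of compound 2.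

The next compound, compound 4 `CC(C)(C)c1ccccc1Oc1ccc(N2CCC[C@H]2CC(=O)O)cc1`, differs from compound 2 by tert-butyl in place of hydrogen on an aromatic carbon. Going by the values given here, no measured step carries a tert-butyl, and none alters a hydrogen ortho to a large group. Among the compounds with values here, the only step on the same part of the molecule, a 1.6-fold lower number from compound 2 to compound 3 (0.19 log units; within the scatter), exchanged the whole ring and still stayed within the scatter, so nothing measured points to a large effect here. The step from compound 2 to compound 4 is therefore expected to be modest, estimated as a 1.4-fold lower number from compound 2 to compound 4 (0.15 log units; within the scatter), with a wide range allowed. Compound 4 is expected to give about 400 nM in this assay, estimated between 130 nM and 1200 nM.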

Compound 4, half-maximal effective concentration: 6500 nM
Beside the measured number, compound 4's estimate is 16-fold (1.21 log units) below it; measured number above the stated range.
By their numbers in this assay, from the lowest: compounds 1, 3 and 2 (each within the scatter of the next, the first and the last beyond it); then compound 4.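

In this assay, tert-butyl in place of hydrogen on an aromatic carbon, ortho to a large group, gives a 12-fold higher number from compound 2 to compound 4 (1.06 log units; beyond the scatter) and so makes a large step on a ring where none had been seen. Substitution of this ring as such does not go with such a rise: a 1.6-fold lower number from compound 2 to compound 3 (0.19 log units; within the scatter) stays within the scatter, while the single tert-butyl of compound 4 lies far beyond it. The compounds shown offer no measurement that accounts for this rise.

Open, from the compounds shown here alone, is whether the rise belongs to tert-butyl itself or to any group on this carbon. Methyl or a single chlorine on the same carbon would separate the two, as would tert-butyl on another carbon of that ring.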